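Pyrimidin-2-yl extension of the aryl amine in the series

The source may report more compounds than this note shows. Statements on the series, on what has been measured and on what is new or still open speak of the compounds shown alone.

Among the compounds with values here, in a functional assay for inhibition of sodium/hydrogen exchanger (Oryctolagus cuniculus) (a lower number here means a stronger inhibitor, a higher number a weaker inhibitor), compound 2 `Cc1cc(N)c(S(C)(=O)=O)cc1C(=O)N=C(N)N` gives 16 nM, the higher of the two numbers measured so far; compound 1 `CCCc1cc(C)c(C(=O)N=C(N)N)cc1S(C)(=O)=O` gives 5.7 nM. Within the data shown here, the single measured step, a 2.8-fold higher number from compound 1 to compound 2 (0.45 log units; beyond the scatter), is the only comparison available. Compound 3 `Cc1cc(Nc2ncccn2)c(S(C)(=O)=O)cc1C(=O)N=C(N)N` is not yet measured and differs from compound 2 by pyrimidin-2-yl in place of hydrogen on a nitrogen on an aromatic ring. Among the measured compounds shown here, no measured step alters a substituent on this nitrogen, so the step from compound 1 to compound 2 bears on the question only indirectly: exchanging propyl for amino moved the number upward, and compound 3 adds back a larger group on that amino nitrogen, though an aromatic ring rather than a chain. The expectation is therefore a step of a 1.6-fold lower number from compound 2 to compound 3 (0.20 log units; within the scatter), a small move toward a lower number that may not exceed the scatter. Compound 3 is estimated at 10 nM, with a range of 3 nM to 35 nM.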

Compound 3, half-maximal inhibitory concentration: 8.3 nM
Beside the measured number, compound 3's estimate is 1.2-fold (0.08 log units) above it; measured number inside the range.
By their numbers in this assay, from the lowest: compounds 1, 3 and 2 (each within the scatter of the next, the first and the last beyond it).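

In this assay, placing pyrimidin-2-yl on the nitrogen in place of hydrogen gives a 1.9-fold lower number from compound 2 to compound 3 (0.29 log units; within the scatter), so this position accepts an aromatic ring of 6 heavy atoms with no step beyond the scatter. Against propyl on the same aromatic carbon, (pyrimidin-2-yl)amino gives a 1.5-fold higher number from compound 1 to compound 3 (0.16 log units; within the scatter), so these two groups cannot be told apart in this assay, whereas amino and propyl could, at a 2.8-fold higher number from compound 1 to compound 2 (0.45 log units; beyond the scatter). No measurement available here explains these numbers.

From the compounds shown here alone, it remains open whether a phenyl ring on the same nitrogen would match pyrimidin-2-yl, which would test the part played by the ring nitrogens. A methyl or acetyl group there would show whether a smaller substituent on this nitrogen also gives numbers within the scatter of compound 3.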